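Tail-ring change from compound 1 to compound 4

The source may hold more compounds than are shown below. What is called first, only, known or untested is meant among the compounds shown, and "the series" means these compounds.

Measured compounds:
compound 1 `O=C(O)CCCc1cn(CC(=O)O)c2c(/C=C/c3ccc(OCCCCc4c(F)ccc(F)c4F)cc3)cccc12` — 2.1 nM
compound 2 `Cc1c(CCCC(=O)O)c2cccc(/C=C/c3ccc(OCCCCc4ccccc4)cc3)c2n1CC(=O)O` — 4.7 nM
compound 3 `Cc1c(Cl)cccc1CCCCOc1ccc(C#Cc2cccc3c(CCCC(=O)O)c(C)n(CCCCC(=O)O)c23)cc1` — 30 nM

All three numbers come from a functional assay on HEK293 cells for antagonist activity at cysteinyl leukotriene receptor 2 (Homo sapiens), read by fluorescence and calcium flux, with stated times of 30 min and 1 h; on this read-out lower numbers stand for stronger inhibition and higher numbers for weaker inhibition. Compound 1 holds the lowest number of the three; compound 2 stands nearest to it, with a gap beyond the usual scatter, and compound 3 lies furthest away. Within the data shown here, compound 2 and compound 3 each differ from compound 1 in more than one place, so no single-change step between measured compounds is available for this series.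

Compound 4 `Cc1c(F)cccc1CCCCOc1ccc(/C=C/c2cccc3c(CCCC(=O)O)cn(CC(=O)O)c23)cc1` has not yet been measured in this assay. It differs from compound 1 in one place: 3-fluoro-2-methylphenyl in place of 2,3,6-trifluorophenyl on a saturated chain carbon, four bonds along the chain from an oxygen on an aromatic ring. The rest of the molecule, from the ether oxygen through the shared core and its two acid chains, is unchanged.

Among the measured compounds shown here, with no measured single-change step to lean on, only a modest step is expected from compound 1 to compound 4, towards a somewhat higher number, at or just beyond the scatter: a 1.9-fold higher number from compound 1 to compound 4 (0.28 log units; within the scatter). Compound 4 is accordingly estimated at 4 nM, with a range from 1.5 nM to 12 nM.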

Compound 4, half-maximal inhibitory concentration: 14 nM
Beside the measured number, compound 4's estimate is 3.5-fold (0.54 log units) below it; measured number outside the range, above it.
By their numbers in this assay, from the lowest: compound 1; then compound 2; then compound 4; then compound 3.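

In this assay, among these compounds, the tail ring on the saturated chain carbon gives the first single-change reading: 3-fluoro-2-methylphenyl in place of 2,3,6-trifluorophenyl gives a 6.7-fold higher number from compound 1 to compound 4 (0.82 log units; beyond the scatter) with the ether oxygen, the shared core and its two acid chains unchanged. The step lies beyond the scatter, so this read-out responds to the substitution on this ring and not only to the core or the acid chains. What about the two rings produces the step cannot be said, as no measurement of any property of these compounds bears on it.

The swap removes fluorine and adds methyl in one change, so the compounds shown do not separate the contribution of each. Also open, on these data alone, is how a pyridine ring, or a shorter chain carrying the 2,3,6-trifluorophenyl ring, would read on this same core.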